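Inverting every stereocentre of compound 1: working notes

The source may hold more compounds than are shown below. What is called first, only, known or untested is meant among the compounds shown, and "the series" means these compounds.

compound 1 `CCOC(=O)C#Cc1c(C(=O)OCC)nnn1[C@@H]1O[C@H](CO)[C@@H](OC(C)C)[C@H]1OC(C)C`: 370 nM
compound 2 `CCOC(=O)C#Cc1c(C(=O)OCC)nnn1[C@@H]1O[C@H](COC)[C@@H](OC(C)C)[C@H]1OC(C)C`: 550 nM
compound 3 `CCOC(=O)C#Cc1c(C(=O)OCC)nnn1[C@@H]1O[C@H](COC(C)=O)[C@@H](OC(C)C)[C@H]1OC(C)C`: 500 nM

All three values come from a functional assay on K562 cells (Homo sapiens), read by XTT assay, with a stated time of 48 h (on this read-out lower numbers stand for stronger inhibition and higher numbers for weaker inhibition), and compound 1 stands level with compounds 2 and 3, as its steps to both lie within the scatter.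

Compound 4 `CCOC(=O)C#Cc1c(C(=O)OCC)nnn1[C@H]1O[C@@H](CO)[C@H](OC(C)C)[C@@H]1OC(C)C` departs from compound 1 as follows: the two compounds have the same atoms and bonds and differ only in configuration as drawn: 4 of 4 stereo elements differ (all stereocentres are inverted: mirror images); a stereocentre at a saturated ring carbon is drawn R in compound 1 and S in compound 4; a stereocentre at a saturated ring carbon is drawn R in compound 1 and S in compound 4; a stereocentre at a saturated ring carbon is drawn R in compound 1 and S in compound 4; a stereocentre at a saturated ring carbon is drawn R in compound 1 and S in compound 4 and so nothing leaves or enters, and the two are mirror images.

The measured steps all change the group on one oxygen: a 1.5-fold higher number from compound 1 to compound 2 (0.17 log units; within the scatter) for methyl in place of hydrogen, a 1.4-fold higher number from compound 1 to compound 3 (0.13 log units; within the scatter) for acetyl in place of hydrogen and a 1.1-fold lower number from compound 2 to compound 3 (0.04 log units; within the scatter) for acetyl in place of methyl. None of them touches configuration, so they bear on compound 4 only loosely. Among the measured compounds shown here, the series holds no measured mirror-image pair, and the data fix neither the size nor the direction of this step.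

The working expectation starts from compound 1 at 370 nM and leans slightly towards a higher number, with a wide allowance on the upper side. The expected step in this assay is a 1.4-fold higher number from compound 1 to compound 4 (0.13 log units; within the scatter) and no firm change beyond the scatter is expected. For compound 4 the estimated value is 500 nM with an expected range from 150 nM to 2500 nM in this assay until a measurement is available.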

Compound 4, half-maximal inhibitory concentration: 200 nM
Compound 4: middle estimate off by 2.5-fold (0.40 log units), on the high side; the range from low to high includes it.
By their numbers in this assay, from the lowest: compounds 4, 1, 3 and 2 (each within the scatter of the next, the first and the last beyond it).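

Inverting all four stereocentres gives, in this assay, a 1.9-fold lower number from compound 1 to compound 4 (0.27 log units; within the scatter), so compounds 1 and 4 stand level on this read-out. Among the compounds shown here, this is the only step that bears on configuration, since the earlier steps changed just the group on one oxygen, and it shows that even complete inversion at the four saturated ring carbons leaves the number within the scatter for this pair. The step can be read as one of configuration alone, because nothing else separates the two compounds: the fact that compounds 1 and 4 differ only in the configuration as drawn

As far as these compounds go, a mirror-image pair says nothing about inverting a single stereocentre, so the behaviour of partly inverted forms remains open, as does whether methyl or acetyl on that oxygen would give the same picture in the configuration of compound 4 as in compounds 2 and 3. The compounds shown also leave open how this cell read-out responds to an amine or a carboxylic acid in place of the hydroxyl group of compound 1, and whether configuration still counts for as little with such a group in that place.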